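Swapping a ring hydroxy for hydrogen: what to expect

The source may report more compounds than this note shows. Statements on the series, on what has been measured and on what is new or still open speak of the compounds shown alone.

- Compound 1 (`COc1cc(O)c2c(c1O)C/C(C)=C\[C@@H](O)C[C@@]1(C)O[C@@H]1C2=O`): 6500 nM
- Compound 2 (`COc1cc(O)c2c(c1O)C[C@]1(C)O[C@@H]1CC[C@@]1(C)O[C@@H]1C2=O`): 4200 nM

Both values come from a functional assay on A549 cells (Homo sapiens) for cytotoxicity, read by MTT assay, with a stated time of 48 h (on this read-out lower numbers stand for stronger inhibition and higher numbers for weaker inhibition), and lie within the usual scatter of repeated measurements of each other. On these numbers, compound 1 therefore cannot be ranked against compound 2, and the two simply sit in the same range.

The unmeasured compound 3 (`COc1cc(O)c2c(c1O)C/C(C)=C\CC[C@@]1(C)O[C@@H]1C2=O`) differs from compound 1 in one place, with hydrogen in place of hydroxy on a saturated ring carbon. For the measured compounds named here, no measured pair here isolates a change of this kind, so the data give no direct guide to its size or direction. Going by the values given here, the only anchor is the value of compound 1 in this assay, so the expectation is a step that stays within the scatter, with no firm direction. The estimated move is small (a 1.2-fold lower number from compound 1 to compound 3 (0.07 log units; within the scatter)) and remains only an expectation until measured. For compound 3 the expected value is 5500 nM (estimated range 2200 nM to 13000 nM).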

Compound 3, half-maximal inhibitory concentration: 16400 nM
The estimate for compound 3 lay 3.0-fold (0.47 log units) below the measured number; measured number outside the range, above it.
By their numbers in this assay, from the lowest: compounds 2 and 1 (each within the scatter of the next); then compound 3.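

In this assay the swap of hydroxy for hydrogen on the saturated ring carbon gives a 2.5-fold higher number from compound 1 to compound 3 (0.40 log units; beyond the scatter) and so moves the read-out toward weaker inhibition. For the compounds shown here, this is the first change in the set that touches a single place, and it shows that this carbon is not a silent spot on the core: with the hydroxy in place, compound 1 gives the lower number, and the gap is larger than repeat measurements alone would be expected to produce. Why removing this one group costs activity cannot be said, as nothing measured here points to a reason.

The compounds shown carry only hydroxy or hydrogen on this carbon, so it stays open whether an amine, a fluorine atom or a carboxylic acid there would match compound 1, fall short of it or go beyond it. As far as these compounds go, it also stays open whether the hydroxy would matter to the same degree on a different core, such as that of compound 2.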